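Replacing an aromatic group on the sulfonyl sulfur with oxan-4-yl

This account rests on a few compounds, and the source may have more. Where it says the series, first, only, none or still open, it means among the compounds named here.

compound 1 `O=C(NCc1ccc(S(=O)(=O)c2cccc(C(F)(F)F)c2)cc1)N1Cc2ccncc2C1`: 14 mL/min/kg
compound 2 `O=C(NCc1ccc(S(=O)(=O)c2cc(F)cc(F)c2)cc1)N1Cc2ccncc2C1`: 8 mL/min/kg
compound 3 `CC(C)n1cc(S(=O)(=O)c2ccc(CNC(=O)N3Cc4ccncc4C3)cc2)cn1`: 4 mL/min/kg

These compounds share a core and differ only in the group on a sulfonyl sulfur. In an ADME assay on microsomes from liver (Homo sapiens) for pharmacokinetics, read by LC-MS, with a stated time of 60 min, tested at 1 uM (on this read-out lower numbers stand for slow clearance and higher numbers for fast clearance), compound 1 stands clearly above compound 3 , but it cannot be told apart from compound 2 . The next compound, not yet measured, is compound 4 `O=C(NCc1ccc(S(=O)(=O)C2CCOCC2)cc1)N1Cc2ccncc2C1`. It has oxan-4-yl in place of 3-(trifluoromethyl)phenyl on a sulfonyl sulfur. Two measured steps replace the same group. The first is a 1.8-fold lower number from compound 1 to compound 2 (0.24 log units; within the scatter), and the second is a 3.5-fold lower number from compound 1 to compound 3 (0.54 log units; beyond the scatter). Neither tests a non-aromatic ring on the sulfonyl sulfur, so the guidance is only indirect. Taking the second step as the closer guide to size, a modest move to a lower number is expected in this assay. The estimated step is a 2.8-fold lower number from compound 1 to compound 4 (0.45 log units; beyond the scatter). For compound 4 the estimated clearance is 5 mL/min/kg, with an expected range from 2.5 mL/min/kg to 11 mL/min/kg.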

Compound 4, clearance: 6 mL/min/kg
The estimate for compound 4 lay 1.2-fold (0.08 log units) below the measured number, within the range that was stated.
By their numbers in this assay, from the lowest: compounds 3, 4, 2 and 1 (each within the scatter of the next, the first and the last beyond it).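

With oxan-4-yl, the only non-aromatic ring in this set, this assay shows a 2.3-fold lower number from compound 1 to compound 4 (0.37 log units; beyond the scatter). An aromatic ring on the sulfonyl sulfur is therefore not required for a number clearly lower than that of compound 1. The other two comparisons, a 1.5-fold higher number from compound 3 to compound 4 (0.18 log units; within the scatter) and a 1.3-fold lower number from compound 2 to compound 4 (0.12 log units; within the scatter), show that this non-aromatic ring cannot be told apart from either the 1-isopropyl-1H-pyrazol-4-yl or the 3,5-difluorophenyl group.

No measurement here bears on what lies behind these steps. As far as these compounds go, it also remains open whether the ring oxygen of oxan-4-yl matters, which cyclohexyl, the same ring made of carbon only, could test, and whether an open chain such as isopropyl would give a similar number.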